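The compounds below may be only part of what the source reports. "The series", "measured", "known", "first", "only" and "open" are said of these compounds alone.

Measured so far:
- compound 1 `O=C1c2c[n+]([O-])c3ccccc3c2C(=O)c2c1c1ccccc1n2Cc1cn(C[C@@H](O)CO)nn1`: 140 nM
- compound 2 `O=C1c2c[n+]([O-])c3ccccc3c2C(=O)c2c1c1ccccc1n2CCN1CCCC1`: 430 nM
- compound 3 `CCCCN1CCN(CCCCn2c3c(c4ccccc42)C(=O)c2c[n+]([O-])c4ccccc4c2C3=O)CC1`: 2150 nM

All three share one core and differ only in the group carried on the chain attached to the aromatic nitrogen. In a functional assay on A-375 cells (Homo sapiens) for cytotoxicity, read by MTT assay, with a stated time of 72 h (on this read-out higher numbers stand for weaker inhibition and lower numbers for stronger inhibition), compound 3 gives the highest number of the three, so on this read-out it is the weakest inhibitor of the set, with compound 2 nearest to it and compound 1 furthest away.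

Compound 4 `O=C1c2c[n+]([O-])c3ccccc3c2C(=O)c2c1c1ccccc1n2CCCCn1ccnc1` is the next step from compound 3. The change is 1H-imidazol-1-yl in place of 4-butylpiperazin-1-yl on a saturated chain carbon, four bonds along the chain from an aromatic nitrogen. Within the data shown here, two measured steps bear on it, since both also swapped the group at the end of that chain: a 3.1-fold higher number from compound 1 to compound 2 (0.49 log units; beyond the scatter) and a 5.0-fold higher number from compound 2 to compound 3 (0.70 log units; beyond the scatter). Each swap moved the number by a modest amount, and each landed beyond the scatter. Among the measured compounds shown here, a modest step is therefore expected again for compound 4, most likely toward a lower number, though the direction is not settled by only two earlier steps.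

Compound 4 is estimated at 900 nM, with a range from 300 nM to 3000 nM. That estimate means a step of a 2.4-fold lower number from compound 3 to compound 4 (0.38 log units; beyond the scatter), which is expected rather than known.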

Compound 4, half-maximal inhibitory concentration: 350 nM
For compound 4 the middle estimate is 2.6-fold (0.41 log units) above the measured one; low and high end bracket the measured number.
By their numbers in this assay, from the lowest: compound 1; then compounds 4 and 2 (each within the scatter of the next); then compound 3.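

In this assay, the two earlier swaps at the end of the chain both raised the number, whereas replacing 4-butylpiperazin-1-yl with 1H-imidazol-1-yl lowers it, with a 6.1-fold lower number from compound 3 to compound 4 (0.79 log units; beyond the scatter) showing that this position can move in either direction. Compound 4 stays level with the pyrrolidine-bearing compound, with a 1.2-fold lower number from compound 2 to compound 4 (0.09 log units; within the scatter) inside the scatter, but does not match the group 1-(2,3-dihydroxypropyl)-1H-1,2,3-triazol-4-yl, with a 2.5-fold higher number from compound 1 to compound 4 (0.40 log units; beyond the scatter) beyond it. No measurement here offers a reason for these shifts.

The swap replaces the whole end group, so the data cannot separate the effect of adding the imidazole ring from that of removing the butyl-bearing piperazine ring. A morpholin-4-yl group or a simple dimethylamino group on the same chain, or 1H-imidazol-1-yl on a longer chain, would help pull these apart.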